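Replacing a Methoxyphenyl Amide with a Phenylurea

A few compounds are considered here, and "the series" means these few. Any claim that something is new, unique, unknown or untested is made for them only; others in the source may bear on it.

Compound 1, `COc1ccc(C(=O)N(C)c2ccc3[nH]c(-c4n[nH]c5ccccc45)cc3n2)cc1`: in a functional assay on KB cells (Homo sapiens) for antiproliferative activity, read by MTT assay, with a stated time of 72 h (a higher number here means a weaker inhibitor, a lower number a stronger inhibitor), compound 1 gives 12900 nM.
Compound 2, `COc1ccc(S(=O)(=O)N(C)c2ccc3[nH]c(-c4n[nH]c5ccccc45)cc3n2)c(OC)c1`: in this assay compound 2 gives 10200 nM.

Compound 1 has the higher of the two numbers, but compound 2 lies within the scatter of it, so no order between them can be drawn. Compound 3, `CN(C(=O)Nc1ccccc1)c1ccc2[nH]c(-c3n[nH]c4ccccc34)cc2n1`, is not yet measured; it differs from compound 1 by anilino in place of 4-methoxyphenyl on a carbonyl carbon. Within the data shown here, no measured pair shows this change, so the size of the step is unknown; a step not beyond the scatter is expected. For compound 3 the expected value is 9000 nM, with a range from 3000 nM to 30000 nM. This estimate corresponds to a step of a 1.4-fold lower number from compound 1 to compound 3 (0.16 log units; within the scatter).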

Compound 3, half-maximal inhibitory concentration: 32 nM
Compound 3: the middle estimate sits 280-fold (2.45 log units) above what was measured; the measured number lies below the stated range.
By their numbers in this assay, from the lowest: compound 3; then compounds 2 and 1 (each within the scatter of the next).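

In this assay, the group on this carbonyl carbon proves decisive: anilino in place of 4-methoxyphenyl gives a 400-fold lower number from compound 1 to compound 3 (2.61 log units; beyond the scatter) and turns the amide of compound 1 into a phenylurea. This single change separates compound 3 clearly from compound 1, so the position tolerates far from every aromatic group equally. Nothing available explains the size of this step.

The compounds shown leave open whether the gain belongs to the urea linkage itself or to the loss of the methoxy group. An anilino group carrying methoxy, or a benzylamino group on the same carbonyl carbon, would begin to separate these two changes.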